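A Methanesulfonamide Gives Way to a Methyl-Oxazole

The compounds below may be only part of what the source reports. "The series", "measured", "known", "first", "only" and "open" are said of these compounds alone.

Two measured compounds share one core. Compound 1 `Cn1nccc1-c1cccc2c1CCC2c1ncc[nH]1` carries a 1-methyl-1H-pyrazol-5-yl group on an aromatic carbon; compound 2 `CS(=O)(=O)Nc1cccc2c1CCC2c1ncc[nH]1` carries methanesulfonamido in that place. In a functional assay on CHO cells for agonist activity at Alpha-1B adrenergic receptor (Homo sapiens), read by FLIPR and calcium flux (a higher number here means that more compound is needed for the effect, a lower number that less compound is needed), compound 1 reaches only the assay limit, > 10000 nM. In this assay compound 2 likewise sits at a limit, > 10000 nM. The step that the two limits leave unreadable from compound 1 to compound 2 therefore cannot be sized, since the limit of > 10000 nM in this assay, at which 2 of the 2 values shown sit, covers both values. Compound 3 `Cc1oncc1-c1cccc2c1CCC2c1ncc[nH]1` has not yet been measured; it differs from compound 2 by 5-methyl-1,2-oxazol-4-yl in place of methanesulfonamido on an aromatic carbon. Within the data shown here, the one measured step, a step that the two limits leave unreadable from compound 1 to compound 2, is the only one bearing on this exchange, and its size is not readable. With both known values at the limit, compound 3 is expected to remain near that limit in this assay, the estimated step being a step that the limit leaves unreadable from compound 2 to compound 3. The estimate for compound 3 in this assay is 15000 nM, between 4000 nM and 60000 nM.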

Compound 3, half-maximal effective concentration: > 10000 nM
Compound 3: a limit, no number; the forecaster's own chance of this, stated with the estimate: 80%; the middle value lies beyond the limit too.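

In this assay compound 3 also gives only a limit, > 10000 nM, so the steps to compound 3 from compound 1 and compound 2 cannot be read, because all three compounds share one limit: the limit of > 10000 nM in this assay, at which 3 of the 3 values shown sit.

The compounds shown leave open how these three groups on the aromatic carbon rank against one another.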